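Compound 3 and a change at its carbonyl carbon

The source may report more compounds than this note shows. Statements on the series, on what has been measured and on what is new or still open speak of the compounds shown alone.

Measured in a functional assay on the whole organism for inhibition, with Rattus norvegicus as the target; on this read-out higher numbers stand for an effect only at larger amounts of compound and lower numbers for an effect already at smaller amounts:
Compound 1 `Cc1ccc(CC(Oc2ccc(C(C)C)cc2)C(=O)O)cc1` gives < 50 mg/kg as a limit of the assay.
Compound 2 `CCCCc1ccc(CC(C)(Oc2ccc(C(C)C)cc2)C(=O)O)cc1` gives 1 mg/kg in a measured number.
Compound 3 `CC(C)c1ccc(OC(C)(Cc2ccc(Cl)cc2)C(=O)NS(=O)(=O)C(F)(F)F)cc1` gives 5 mg/kg in a measured number.

Of the two exact numbers, the higher belongs to compound 3, and its gap to compound 2 lies beyond the usual scatter. The remaining value, for compound 1, is a limit and cannot be placed against them.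

Compound 4 `CC(C)c1ccc(OC(C)(Cc2ccc(Cl)cc2)C(=O)CO)cc1` keeps the rest of compound 3 but carries hydroxymethyl in place of ((trifluoromethyl)sulfonyl)amino on a carbonyl carbon. For the measured compounds named here, no measured pair of compounds shows what a single change of this kind does, so the expectation is loose. A move to a higher number in this assay, beyond the scatter, is expected, and the estimated size is a 3.0-fold higher number from compound 3 to compound 4 (0.48 log units; beyond the scatter) in this account. For compound 4 the expected value is 15 mg/kg with an estimated range from 3 mg/kg to 60 mg/kg in the same assay.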

Compound 4, dose for half-maximal effect: > 10 mg/kg
Compound 4: a limit, no number (the forecaster's own chance of this, stated with the estimate: 25%); the middle value does not contradict the limit.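

For the compounds shown here, this is the first read on the carbonyl carbon of compound 3, as none of the earlier compounds differ from one another at this place alone. In this assay, replacing ((trifluoromethyl)sulfonyl)amino with hydroxymethyl gives an at least 2.0-fold higher number from compound 3 to compound 4 (0.30 log units; that floor lies within the scatter), so a shift beyond the scatter is neither shown nor excluded. The result for compound 4 is a limit and not a number: the limit of > 10 mg/kg in this assay, at which 1 of the 4 values shown sits.

On these data alone, the full size of this step therefore remains unknown, and with it how much of the value of compound 3 depends on the ((trifluoromethyl)sulfonyl)amino group. Going by these compounds alone, also open is how a smaller group on the same carbonyl carbon, such as amino or methoxy, would read in this assay, since the single step here cannot separate the loss of the ((trifluoromethyl)sulfonyl)amino group from the arrival of hydroxymethyl.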